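Removing a Dioxolane Ring to Reveal a Diol

A few compounds are considered here, and "the series" means these few. Any claim that something is new, unique, unknown or untested is made for them only; others in the source may bear on it.

Of the compounds shown here, three sharing one core have been measured in a functional assay on MDA-MB-231 cells (Homo sapiens) for cytotoxicity, read by MTT assay, with a stated time of 72 h; on this read-out higher numbers stand for weaker inhibition and lower numbers for stronger inhibition. Compound 1 `O=C1c2c[n+]([O-])c3ccccc3c2C(=O)c2c1c1ccccc1n2CCCCn1ccnc1` gives 210 nM, compound 2 `CCCCN1CCN(CCCCn2c3c(c4ccccc42)C(=O)c2c[n+]([O-])c4ccccc4c2C3=O)CC1` gives 900 nM, and compound 3 `CC1(C)OC[C@H](Cn2cc(Cn3c4c(c5ccccc53)C(=O)c3c[n+]([O-])c5ccccc5c3C4=O)nn2)O1` gives 530 nM. Compound 3 therefore carries the second highest of the three numbers in this assay: its number sits within the usual scatter of that of compound 2, while the number of compound 1 is lower by more than the scatter.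

Compound 4 `O=C1c2c[n+]([O-])c3ccccc3c2C(=O)c2c1c1ccccc1n2Cc1cn(C[C@@H](O)CO)nn1` differs from compound 3 in one place: 1,2-dihydroxyethyl in place of 2,2-dimethyl-1,3-dioxolan-4-yl on a saturated chain carbon bound to an aromatic nitrogen.

Going by the values given here, no measured step touches this part of the molecule. Among the compounds with values here, the only measured step, a 4.3-fold higher number from compound 1 to compound 2 (0.63 log units; beyond the scatter), concerns a group four bonds along the chain from an aromatic nitrogen and so offers no direct guide. With nothing pointing either way, no step beyond the scatter is expected, so in this assay compound 4 is estimated at 530 nM, with a range from 220 nM to 1300 nM, which means an expected step of no change at the digits printed from compound 3 to compound 4 (within the scatter).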

Compound 4, half-maximal inhibitory concentration: 670 nM
Compound 4: middle estimate off by 1.3-fold (0.10 log units), on the low side; the measured number falls inside the stated range.
By their numbers in this assay, from the lowest: compound 1; then compounds 3, 4 and 2 (each within the scatter of the next).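

In this assay, opening the 2,2-dimethyl-1,3-dioxolan-4-yl ring to give 1,2-dihydroxyethyl produces a 1.3-fold higher number from compound 3 to compound 4 (0.10 log units; within the scatter) and so cannot be told apart from no effect, even though the ring goes and two hydrogen-bond donors arrive. At this place on a saturated chain carbon bound to an aromatic nitrogen, the protected and free diol therefore read alike, whereas the larger exchange of 3-(1H-imidazol-1-yl)propyl for 1-(2,3-dihydroxypropyl)-1H-1,2,3-triazol-4-yl gives a 3.2-fold higher number from compound 1 to compound 4 (0.50 log units; beyond the scatter) and does register. Nothing measured on these compounds offers a reason for either step.

Going by these compounds, how a single hydroxyl, a primary amine or a carboxylic acid would read on the same chain carbon remains open. So does whether the mirror-image diol would match compound 4.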